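Aryl swap on the carbonyl carbon: step to compound 4

The compounds below may be only part of what the source reports. "The series", "measured", "known", "first", "only" and "open" are said of these compounds alone.

Compound 1 `COc1cc(-c2cc(/C=C/C(=O)c3ccc(N)cc3)[nH]n2)cc(OC)c1OC` in a functional assay on MDA-MB-231 cells (Homo sapiens) for inhibition, read by sulforhodamine B assay, with a stated time of 48 h (on this read-out higher numbers stand for weaker inhibition of growth and lower numbers for stronger inhibition of growth), gives 12200 nM.
Compound 2 `COc1cc(-c2cc(/C=C/C(=O)c3ccc(Cl)c(Cl)c3)[nH]n2)cc(OC)c1OC` gives only a limit of this assay, > 100000 nM.
Compound 3 `COc1ccc(C(=O)/C=C/c2cc(-c3cc(OC)c(OC)c(OC)c3)n[nH]2)cc1OC` in this assay gives 3060 nM.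

Compound 3 stands at the lowest of the two numbers shown; the nearest number is that of compound 1, shown by a 4.0-fold lower number from compound 1 to compound 3 (0.60 log units; beyond the scatter). The value of compound 2 is a limit, (the limit of > 100000 nM in this assay, at which 1 of the 3 values shown sits), so its distance from compound 3 is known only as a lower bound, an at least 32-fold lower number from compound 2 to compound 3 (1.51 log units; beyond the scatter).

Compound 4 `COc1cc(-c2cc(/C=C/C(=O)c3ccc(F)c(F)c3)[nH]n2)cc(OC)c1OC` has not been measured. It differs from compound 3 in one place: 3,4-difluorophenyl in place of 3,4-dimethoxyphenyl on a carbonyl carbon. Among the compounds with values here, two measured steps bear on it. Within the data shown here, both aryl groups carrying a halogen pair at the same two positions have been seen only in compound 2, whose limit is far removed from compound 3, an at least 32-fold lower number from compound 2 to compound 3 (1.51 log units; beyond the scatter), and also from compound 1, an at least 8.1-fold higher number from compound 1 to compound 2 (0.91 log units; beyond the scatter). The difluoro pair is not the dichloro pair, so the full distance need not recur, but the direction is expected to be the same: a higher number in this assay, and a large one. Compound 4 is therefore expected to give 30000 nM, with a range from 8000 nM to 100000 nM. The expected step is a 9.8-fold higher number from compound 3 to compound 4 (0.99 log units; beyond the scatter).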

Compound 4, concentration for total growth inhibition: 4580 nM
For compound 4 the middle estimate is 6.6-fold (0.82 log units) above the measured one; the measured number lies below the stated range.
By their numbers in this assay, from the lowest: compounds 3 and 4 (each within the scatter of the next); then compound 1. At a limit, above all of these: compound 2.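

In this assay, a halogen pair on the aryl group at the carbonyl carbon is not poorly tolerated as such: 3,4-difluorophenyl and 3,4-dimethoxyphenyl cannot be told apart, a 1.5-fold higher number from compound 3 to compound 4 (0.18 log units; within the scatter), and 3,4-difluorophenyl also improves on 4-aminophenyl, a 2.7-fold lower number from compound 1 to compound 4 (0.43 log units; beyond the scatter). The sharp drop therefore goes with 3,4-dichlorophenyl specifically and not with every halogen pair, as the step between the two pairs shows, an at least 21-fold lower number from compound 2 to compound 4 (1.33 log units; beyond the scatter). The value of compound 2 is a limit, not a number: the limit of > 100000 nM in this assay, at which 1 of the 4 values shown sits.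

The compounds shown do not say where between 3,4-difluorophenyl and 3,4-dichlorophenyl the tolerance ends, which a phenyl with one chlorine and one fluorine, or a phenyl with a single chlorine, would help to place. From the compounds shown here alone, whether a trifluoromethyl group or a carboxylic acid on this aryl group is accepted also remains open.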